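Compound 3 to compound 4: losing the ethenyl link

The source may report more compounds than this note shows. Statements on the series, on what has been measured and on what is new or still open speak of the compounds shown alone.

In a functional assay on NCI-H460 cells (Homo sapiens) for cytotoxicity, read by MTT assay, with a stated time of 48 h (a higher number here means a weaker inhibitor, a lower number a stronger inhibitor), compound 3 `C=C1C(=O)O[C@H]2CC3=C[C@H](C/C(C)=C/[C@@H](OC(=O)/C=C/c4ccncc4)[C@H]12)OC3=O` gives 2100 nM. Compound 2 `C=C1C(=O)O[C@H]2CC3=C[C@H](C/C(C)=C/[C@@H](OC(=O)CC(C)C)[C@H]12)OC3=O` gives 3800 nM. The gap between these two is a 1.8-fold lower number from compound 2 to compound 3 (0.26 log units; within the scatter), so neither stands apart from the other. Compound 1 `C=C1C(=O)O[C@H]2CC3=C[C@H](C/C(C)=C/[C@@H](OC(=O)/C=C/c4ccccc4)[C@H]12)OC3=O` gives > 10000 nM, which is a limit of the assay and not a number. The two steps away from that limit are an at least 2.6-fold lower number from compound 1 to compound 2 (0.42 log units; beyond the scatter) and an at least 4.7-fold lower number from compound 1 to compound 3 (0.67 log units; beyond the scatter).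

Compound 4 `C=C1C(=O)O[C@H]2CC3=C[C@H](C/C(C)=C/[C@@H](OC(=O)c4ccncc4)[C@H]12)OC3=O` has pyridin-4-yl in place of 2-(pyridin-4-yl)ethenyl on a carbonyl carbon. Within the data shown here, no measured step removes the ethenyl link alone, so the estimate rests on indirect evidence. Compound 4 keeps the pyridin-4-yl group whose swap for phenyl gave an at least 4.7-fold lower number from compound 1 to compound 3 (0.67 log units; beyond the scatter), which argues against a return to the limit. The same carbonyl carbon also took a complete exchange of substituent in a 1.8-fold lower number from compound 2 to compound 3 (0.26 log units; within the scatter), without a change beyond the scatter. A small drift towards a higher number is possible, but the expected step is a 1.4-fold higher number from compound 3 to compound 4 (0.15 log units; within the scatter), which means none beyond the scatter in this assay. For compound 4 the estimated value is 3000 nM, with an expected range from 1200 nM to 8000 nM.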

Compound 4, half-maximal inhibitory concentration: 5600 nM
For compound 4 the middle estimate is 1.9-fold (0.27 log units) below the measured one, and the stated range covers the measured number.
By their numbers in this assay, from the lowest: compounds 3, 2 and 4 (each within the scatter of the next, the first and the last beyond it). At a limit, above all of these: compound 1.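

Working from this assay, the ethenyl link on this carbonyl carbon now has a measured step of its own, with the pyridin-4-yl ring kept and only the link removed: a 2.7-fold higher number from compound 3 to compound 4 (0.43 log units; beyond the scatter). The substituent here therefore tolerates a full exchange of group without a readable change, as in a 1.5-fold higher number from compound 2 to compound 4 (0.17 log units; within the scatter), yet a change confined to the link gives a step beyond the scatter, so compound 2 sits within the scatter of both pyridin-4-yl esters while those two stand apart. The comparison with the phenyl analogue says little, as an at least 1.7-fold lower number from compound 1 to compound 4 (0.25 log units; that floor lies within the scatter) gives only a floor, and compound 4 is not shown to stand apart from compound 1, whose entry is a limit of the assay and not a number: the limit of > 10000 nM in this assay, at which 1 of the 4 values shown sits.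

Going by these compounds, it remains open whether the step follows the double bond or the length of the link, which a 2-(pyridin-4-yl)ethyl group on the same carbonyl carbon would separate. Also open, on these data alone, is whether the ring nitrogen still counts without the link, which phenyl placed directly on that carbonyl carbon would test.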